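Swapping the distal aryl group on a shared kinase-inhibitor-like core

This account rests on a few compounds, and the source may have more. Where it says the series, first, only, none or still open, it means among the compounds named here.

Two measured compounds set the scene. Compound 1 `COc1ccc(-c2ccnc(C(=O)Nc3ccc(Oc4ccnc5cc(OCCCN6CCN(C)CC6)c(OC)cc45)c(F)c3)c2)c(OC)c1` carries a 2,4-dimethoxyphenyl group on the pyridine that bears the amide, and in a functional assay on HT-29 cells (Homo sapiens) for cytotoxicity, read by MTT assay, with a stated time of 72 h (on this read-out lower numbers stand for stronger inhibition and higher numbers for weaker inhibition), compound 1 gives 420 nM. Compound 2 `COc1cc2c(Oc3ccc(NC(=O)c4cc(-c5ccc(F)cc5)ccn4)cc3F)ccnc2cc1OCCCN1CCCC1` instead carries a 4-fluorophenyl group there and a different side chain on the other end of the molecule; in this assay compound 2 gives 430 nM. The two values lie on top of each other, and the gap between them is within the usual scatter, so neither can be called the more potent of the pair.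

Compound 3 `COc1ccc(-c2ccnc(C(=O)Nc3ccc(Oc4ccnc5cc(OCCCN6CCCC6)c(OC)cc45)c(F)c3)c2)c(OC)c1` is the unmeasured one. It differs from compound 2 in a single place: 2,4-dimethoxyphenyl in place of 4-fluorophenyl on an aromatic carbon. For the measured compounds named here, since compound 1 and compound 2 differ in two places at once, no clean step for this exact change exists among the measured compounds; both measured numbers simply sit close together. The expectation is therefore a step from compound 2 to compound 3 of a 1.1-fold lower number from compound 2 to compound 3 (0.03 log units; within the scatter), that is, no change beyond the scatter. Compound 3 is estimated at 400 nM, with a range from 150 nM to 1100 nM.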

Compound 3, half-maximal inhibitory concentration: 630 nM
The estimate for compound 3 lay 1.6-fold (0.20 log units) below the measured number; the range from low to high includes it.
By their numbers in this assay, from the lowest: compounds 1, 2 and 3 (each within the scatter of the next).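

In this assay, the exchange on the aromatic carbon opposite the ring nitrogen can now be read on its own: 2,4-dimethoxyphenyl in place of 4-fluorophenyl gives a 1.5-fold higher number from compound 2 to compound 3 (0.17 log units; within the scatter), even though the entering group has 10 heavy atoms and 2 hydrogen-bond acceptors, and the leaving group has 7 and 0. The other end of the molecule can also be read separately, as pyrrolidin-1-yl in place of 4-methylpiperazin-1-yl on the saturated chain gives a 1.5-fold higher number from compound 1 to compound 3 (0.18 log units; within the scatter), so neither single change moves the number beyond the usual scatter of this cytotoxicity read-out. Nothing available here explains why these steps are so small.

From the compounds shown here alone, it remains open how a plain phenyl group, a 4-methoxyphenyl group or a phenyl ring bearing a carboxylic acid or an amine would compare at this position. Going by these compounds, on the other end of the molecule, the effect of a morpholine ring or a longer chain in place of the present side chain also remains open.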